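The source may hold more compounds than are shown below. What is called first, only, known or untested is meant among the compounds shown, and "the series" means these compounds.

Measured compounds:
compound 1, `CCc1cc(Cc2cccc(OC)c2)c(=O)n(CC(=O)Nc2ccc(I)cc2)n1` — in a functional assay on HL-60 cells (Homo sapiens), read by calcium flux (a lower number here means that less compound is needed, a higher number that more compound is needed for the effect), compound 1 gives > 50000 nM, which is a limit of the assay and not a number.
compound 2, `COc1ccc(Cc2cc(-c3cccs3)nn(CC(=O)Nc3ccc(Br)cc3)c2=O)cc1` — in this assay compound 2 gives > 50000 nM, again a limit and not a number.

Compound 2 therefore stands at the limit of > 50000 nM in this assay, at which 2 of the 2 values shown sit; no value in the series is a measured number, and nothing separates compound 2 from compound 1 on the figures shown. Among the compounds with values here, no step between two measured compounds is available, so no measured direction exists for the series.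

The next compound is compound 3, `COc1ccc(Cc2cc(-c3ccc(OC)cc3)nn(CC(=O)Nc3ccc(Br)cc3)c2=O)cc1`. It differs from compound 2 in one place: 4-methoxyphenyl in place of thiophen-2-yl on an aromatic carbon. Within the data shown here, with no measured step to draw on, the expectation for compound 3 in this assay is that the change brings nothing beyond the usual scatter and that the limit is most likely reported again. The step implied by this estimate, a step that the limit leaves unreadable from compound 2 to compound 3, is expected to be none beyond the scatter. Compound 3 is estimated at 80000 nM, with a range from 25000 nM to 300000 nM.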

Compound 3, half-maximal effective concentration: > 50000 nM
Compound 3: no number, only a limit (the forecaster's own chance of this, stated with the estimate: 85%); the middle value lies beyond the limit too.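

Compound 2 and compound 3 both sit at a limit and not at a number, so no step can be read between them for 4-methoxyphenyl in place of thiophen-2-yl: the limit of > 50000 nM in this assay, at which 3 of the 3 values shown sit.

The compounds shown leave open whether any change to the shared core gives a readable value in this assay, and how these two groups compare.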